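Nitro in place of chloro: expected cytotoxicity on MCF7 cells

A few compounds are considered here, and "the series" means these few. Any claim that something is new, unique, unknown or untested is made for them only; others in the source may bear on it.

Measured so far:
compound 1, structure `Cc1cnc(C(=O)NN2C(=O)CS[C@@H]2c2ccc([N+](=O)[O-])cc2)cn1`, gives a limit of > 100 ug/mL
compound 2, structure `O=C(NN1C(=O)CS[C@@H]1c1ccc(Cl)cc1)c1cnccn1`, gives a limit of > 100 ug/mL

In an ADME assay on MCF7 cells (Homo sapiens) for cytotoxicity, read by MTT assay, with a stated time of 4 days (on this read-out lower numbers stand for stronger inhibition and higher numbers for weaker inhibition), compound 2 stands at the limit of the assay rather than at a number. Compound 1 stands at the same limit, so the two values show no difference between them; both sit at the limit of > 100 ug/mL in this assay, at which 2 of the 2 values shown sit. Among the compounds with values here, no step between measured compounds is available, and nothing in the pair separates the chloro from the nitro substituent in this read-out.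

Compound 3, structure `O=C(NN1C(=O)CS[C@@H]1c1ccc([N+](=O)[O-])cc1)c1cnccn1`, differs from compound 2 by nitro in place of chloro on an aromatic carbon. The expectation for the step from compound 2 to compound 3 in this assay is none beyond the scatter, and most likely a further limit, because compound 2 gives > 100 ug/mL. Compound 3 is therefore estimated at 150 ug/mL, expected range 60 ug/mL to 400 ug/mL, which means an expected step that the limit leaves unreadable from compound 2 to compound 3.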

Compound 3, half-maximal inhibitory concentration: 65.6 ug/mL
For compound 3 the middle estimate is 2.3-fold (0.36 log units) above the measured one; the measured number falls inside the stated range.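

In this assay, within the data shown here, compound 3 gives 65.6 ug/mL, the first number rather than a limit. On an aromatic carbon para to a large group, nitro in place of chloro gives an at least 1.5-fold lower number from compound 2 to compound 3 (0.18 log units; that floor lies within the scatter), while hydrogen in place of methyl on an aromatic carbon gives an at least 1.5-fold lower number from compound 1 to compound 3 (0.18 log units; that floor lies within the scatter). Both steps start from a limit, so their full size cannot be read: the limit of > 100 ug/mL in this assay, at which 2 of the 3 values shown sit.

The compounds shown leave open whether an amine or a carboxylic acid in place of the nitro group would also give a number in this assay. They also leave open whether hydrogen in place of methyl would give a comparable step with chloro on the aromatic ring.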